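Tert-butoxy in place of the chain of compound 1

This account rests on a few compounds, and the source may have more. Where it says the series, first, only, none or still open, it means among the compounds named here.

Measured in a functional assay on MCF7 cells (Homo sapiens) for antiproliferative activity, read by luminescence, with a stated time of 24 h; a higher number here means a weaker inhibitor, a lower number a stronger inhibitor:
compound 1 `CC(=O)NCCNC(=O)CCC(=O)Oc1c(C)c(C)c2c(c1C)CCC(C)(COc1ccc(/C=C3\SC(=O)NC3=O)cc1)O2`: > 50000 nM
compound 2 `Cc1cc(C)c2c(c1C)OC(C)(COc1ccc(CC3SC(=O)NC3=O)cc1)CC2`: 20000 nM
compound 3 `Cc1c(C)c2c(c(C)c1OC(=O)CCCC[C@@H]1SC[C@@H]3NC(=O)N[C@@H]31)CCC(C)(COc1ccc(/C=C3\SC(=O)NC3=O)cc1)O2`: 11200 nM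

Compound 1 gives > 50000 nM, and this is a limit of the assay, not a number. Its standing in the series is therefore known only as the limit of > 50000 nM in this assay, at which 1 of the 3 values shown sits. Compound 2 gives 20000 nM and compound 3 gives 11200 nM.

Compound 4 `Cc1c(C)c2c(c(C)c1OC(=O)OC(C)(C)C)CCC(C)(COc1ccc(/C=C3\SC(=O)NC3=O)cc1)O2` keeps the core of compound 1 and changes in one place. On a carbonyl carbon, tert-butoxy enters in place of 2-((2-acetamidoethyl)carbamoyl)ethyl: tert-butoxy in place of 2-((2-acetamidoethyl)carbamoyl)ethyl on a carbonyl carbon.

Within the data shown here, one measured step bears on this change: an at least 4.4-fold lower number from compound 1 to compound 3 (0.64 log units; beyond the scatter). It alters the same chain of compound 1 and lies beyond the scatter, but it keeps part of that chain, whereas compound 4 loses all of it. No measurement shows a replacement of the whole chain by tert-butoxy, so the step offers only a rough guide. Resting on compound 3 at 11200 nM, a step of similar size towards a lower number is expected in this assay. Compound 4 may also return only a limit. The expected step is an at least 3.5-fold lower number from compound 1 to compound 4 (0.55 log units; beyond the scatter). For compound 4 the estimated value is 14000 nM, with an expected range from 5000 nM to 50000 nM.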

Compound 4, half-maximal inhibitory concentration: 7700 nM
The estimate for compound 4 lay 1.8-fold (0.26 log units) above the measured number, within the range that was stated.
By their numbers in this assay, from the lowest: compounds 4, 3 and 2 (each within the scatter of the next, the first and the last beyond it). At a limit, above all of these: compound 1.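

In this assay, the whole 2-((2-acetamidoethyl)carbamoyl)ethyl chain on this carbonyl carbon can be given up, and tert-butoxy in its place brings an at least 6.4-fold lower number from compound 1 to compound 4 (0.81 log units; beyond the scatter). The earlier step at this position, an at least 4.4-fold lower number from compound 1 to compound 3 (0.64 log units; beyond the scatter), kept part of the chain and brought in a group with two rings, whereas tert-butoxy has no ring and 0 hydrogen-bond donors, yet the values of compound 3 and compound 4 lie within the scatter of each other, so a ring-bearing group on this chain is not needed to reach this range of values. Compound 1 enters this comparison only as a limit, so the step gives a minimum size and not a measured one: the limit of > 50000 nM in this assay, at which 1 of the 4 values shown sits.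

The compounds shown leave open how far the number depends on the size of the group on this carbonyl carbon, as a smaller methyl, a longer alkyl chain or a chain ending in a carboxylic acid or an amine could show. They also leave open whether tert-butoxy would bring a similar step on the saturated core of compound 2, which has a hydrogen in place of the whole ester group.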